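The compounds below may be only part of what the source reports. "The series", "measured", "known", "first", "only" and "open" are said of these compounds alone.

Compound 1 `COc1ccc2c(OCCn3c(=O)oc4cc(C)ccc43)ccnc2c1` gives > 500 nM in a functional assay on EBC-1 cells (Homo sapiens) for inhibition, read by sulforhodamine B assay, with a stated time of 72 h; a higher number here means a weaker inhibitor, a lower number a stronger inhibitor; this is a limit of the assay, not a number.
Compound 2 `Cc1ccc2c(c1)oc(=O)n2CCOc1ccnc2cc(OCCCN3CCCC3)ccc12` gives > 500 nM; this too is a limit.
Compound 3 `Cc1ccc2c(c1)oc(=O)n2CCOc1ccnc2cc(-c3cnn(C)c3)ccc12` gives 35 nM.

Compound 1 thus stands at the limit of > 500 nM in this assay, at which 2 of the 3 values shown sit. Because of this, the step that the two limits leave unreadable from compound 1 to compound 2 cannot be read. Among the measured compounds shown here, the step of an at least 14-fold lower number from compound 1 to compound 3 (1.15 log units; beyond the scatter) is large, as is an at least 14-fold lower number from compound 2 to compound 3 (1.15 log units; beyond the scatter); both bring in 1-methyl-1H-pyrazol-4-yl in place of a substituent on the quinoline-side ring of the shared core, and both lead to the only numbered value in the set.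

Compound 4 `COc1ccc2c(OCCn3c(=O)oc4cc(N)ccc43)ccnc2c1` is unmeasured. Its change from compound 1 is amino in place of methyl on an aromatic carbon. For the measured compounds named here, this change sits on the other ring system of the core, where none of the measured steps touched, so no measured step bears directly on it, and the two large steps concern a different position and a different kind of group. Compound 1 itself offers only a limit to start from.

Compound 4 is therefore expected to stay near the limit, with an estimated step that the limit leaves unreadable from compound 1 to compound 4 that is not distinguishable from no change. The estimate for compound 4 in this assay is 700 nM, within a range from 200 nM to 3000 nM.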

Compound 4, half-maximal inhibitory concentration: 160 nM
Beside the measured number, compound 4's estimate is 4.4-fold (0.64 log units) above it; measured number below the stated range.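

Among the compounds shown here, changing methyl to amino on this aromatic carbon gives an at least 3.1-fold lower number from compound 1 to compound 4 (0.49 log units; beyond the scatter) in this assay, at a place on the core that no earlier step touched. The earlier readable steps had shown a change only with 1-methyl-1H-pyrazol-4-yl on a different aromatic carbon, so this result adds a second place where one change moves the number beyond the scatter, and here the swap is of just one heavy atom, a carbon for a nitrogen, with one hydrogen-bond donor and one hydrogen-bond acceptor entering. The true size of this step stays unknown because compound 1 gives only a limit, not a number, and so the step sets a minimum: the limit of > 500 nM in this assay, at which 2 of the 4 values shown sit.

The compounds shown leave open whether amino and 1-methyl-1H-pyrazol-4-yl would add up in one molecule, as each has been seen only on its own. They also leave open whether other groups on this same carbon, such as a hydroxyl, a methylamino or an acetamide, would give a lower number than methyl does, or whether amino stands alone here.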